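The source may report more compounds than this note shows. Statements on the series, on what has been measured and on what is new or still open speak of the compounds shown alone.

In a functional assay on HCT-116 cells (Homo sapiens) for antiproliferative activity, read by MTT assay, with a stated time of 48 h (on this read-out higher numbers stand for weaker inhibition and lower numbers for stronger inhibition), compound 1 `COc1ccc(-c2cc3c(cn2)[nH]c(=O)n3-c2cc(OC)c(OC)c(OC)c2)cc1C` gives 1810 nM and compound 2 `COc1ccc(-c2cc3c(cn2)[nH]c(=O)n3-c2cc(OC)c(OC)c(OC)c2)cc1N` gives 820 nM, the lower of the two numbers. Compound 3 `COc1ccc(-c2cc3c(cn2)[nH]c(=O)n3-c2cc(OC)c(OC)c(OC)c2)cc1C(=O)O` carries carboxy in place of amino on an aromatic carbon, ortho to a methoxy group: carboxy in place of amino on an aromatic carbon. Going by the values given here, the only measured step at that carbon, a 2.2-fold lower number from compound 1 to compound 2 (0.34 log units; beyond the scatter), is modest and involves no carboxy, so it offers a weak guide. A larger step toward a higher number is expected in this assay, estimated as a 4.9-fold higher number from compound 2 to compound 3 (0.69 log units; beyond the scatter). In this assay the expected value for compound 3 is 4000 nM, with an estimated range from 1200 nM to 14000 nM.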

Compound 3, half-maximal inhibitory concentration: 3070 nM
Compound 3: middle estimate off by 1.3-fold (0.11 log units), on the high side; the range from low to high includes it.
By their numbers in this assay, from the lowest: compound 2; then compounds 1 and 3 (each within the scatter of the next).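

In this assay the change from 3-amino-4-methoxyphenyl to 3-carboxy-4-methoxyphenyl gives a 3.7-fold higher number from compound 2 to compound 3 (0.57 log units; beyond the scatter), so the advantage of amino at this carbon now holds against two other groups rather than one. Carboxy and methyl are not separated here, with a 1.7-fold higher number from compound 1 to compound 3 (0.23 log units; within the scatter), which leaves amino alone with the lowest number of the three. No measurement shown explains why amino differs from the other two groups. Open, as far as these compounds go, is whether a hydroxyl, a primary amide or a methyl ester at this carbon would match amino, and whether an acetylated amine would keep its advantage.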